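The source may report more compounds than this note shows. Statements on the series, on what has been measured and on what is new or still open speak of the compounds shown alone.

Working notes on a small series read in a functional assay on T98G cells (Homo sapiens) for inhibition, read by MTT assay, with a stated time of 72 h; a lower number here means a stronger inhibitor, a higher number a weaker inhibitor. Compound 1 (`CC1(C)CC(NC(=S)Nc2ccccc2)c2cc(Cl)ccc2O1`) gives 37000 nM, and compound 2 (`CC1(C)CC(NC(=S)NCc2ccccc2)c2cc(Br)ccc2O1`) gives 54000 nM. These two values lie within the scatter of each other, so compound 2 stands level with compound 1 on the numbers available, and neither ranks ahead.

Compound 3 (`CC1(C)CC(NC(=S)NCc2ccccc2)c2cc(Cl)ccc2O1`) has not yet been measured. It departs from compound 2 at one place, with chloro in place of bromo on an aromatic carbon. Among the measured compounds shown here, no two measured compounds differ in one place only, so the data give no direct size for this exchange in this assay. No change beyond the scatter is expected in either direction. This expectation takes compound 2 at 54000 nM as its anchor, and compound 1, also a chloro compound, sits at 37000 nM in the same range. The estimated 1.1-fold lower number from compound 2 to compound 3 (0.05 log units; within the scatter) stays within the scatter. For compound 3 the expected value is 48000 nM, with an estimated range from 22000 nM to 100000 nM.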

Compound 3, half-maximal inhibitory concentration: 99000 nM
The estimate for compound 3 lay 2.1-fold (0.31 log units) below the measured number; the range from low to high includes it.
By their numbers in this assay, from the lowest: compounds 1, 2 and 3 (each within the scatter of the next, the first and the last beyond it).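

In this assay the exchange of bromo for chloro on an aromatic carbon now has a size (a 1.8-fold higher number from compound 2 to compound 3 (0.26 log units; within the scatter)), so at this place, meta to a fused ring and para to a fused ring, this single pair does not separate the two halogens. Among the compounds shown here, with chloro present in both compounds, the series also gains its first reading at the nitrogen, where benzyl in place of phenyl on an amide-type nitrogen gives a modest step (a 2.7-fold higher number from compound 1 to compound 3 (0.43 log units; beyond the scatter)), the only one of the two steps that lies beyond the scatter. No measured information on any property of these groups bears on either step, and neither can be explained from what is shown.

The compounds shown leave open whether the benzyl-for-phenyl step would carry over to a bromo compound, since each step rests on one pair only. They also leave open how fluoro or methoxy would read on this aromatic carbon, and how a longer chain such as phenethyl would read on the nitrogen.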